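The source may hold more compounds than are shown below. What is called first, only, known or untested is meant among the compounds shown, and "the series" means these compounds.

Measured compounds in an ADME assay on microsomes from liver (Homo sapiens) for metabolic stability, with a stated time of 10 min; on this read-out higher numbers stand for a more stable compound and lower numbers for a less stable compound:
compound 1 `O=C(NS(=O)(=O)c1ccccc1)c1ccc(Nc2nc(NC3(c4ccc(Cl)cc4)CC3)nc(OCC(F)(F)F)n2)cc1`, 100%
compound 2 `CC(C)(C)OC(=O)NCCS(=O)(=O)NC(=O)c1ccc(Nc2nc(NC3(c4ccc(Cl)cc4)CC3)nc(OCC(F)(F)F)n2)cc1`, 92%
compound 3 `CCCCCNc1nc(Nc2ccc([N+](=O)[O-])cc2)nc(OCC(F)(F)F)n1`, 74%

Going by the values given here, compound 2 lies within the scatter of compound 1 and stands above compound 3; compound 3 shares no single-site step with either of them. Among the compounds with values here, the only single-site step measured is a number 8 percentage points lower from compound 1 to compound 2 (within the scatter), a change on the sulfonyl sulfur. Compound 4 `CC(=O)NCCS(=O)(=O)NC(=O)c1ccc(Nc2nc(NC3(c4ccc(Cl)cc4)CC3)nc(OCC(F)(F)F)n2)cc1` differs from compound 2 by methyl in place of tert-butoxy on a carbonyl carbon. Within the data shown here, no measured step touches this carbonyl carbon, so the expectation rests on the neighbouring change alone, which stayed within the scatter while both compounds concerned remained near the top of this assay. For compound 4 the expected step is a number 4 percentage points lower from compound 2 to compound 4 (within the scatter), not beyond the scatter. Compound 4 is estimated at 88%, range 72% to 100%.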

Compound 4, percent of the compound remaining: 95%
Compound 4: middle estimate off by 7 percentage points, on the low side; measured number inside the range.
By their numbers in this assay, from the lowest: compound 3; then compounds 2, 4 and 1 (each within the scatter of the next).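

In this assay the carbonyl carbon now has a measured step, a number 3 percentage points higher from compound 2 to compound 4 (within the scatter) with methyl in place of tert-butoxy, so 5 heavy atoms give way to 1 without leaving the scatter. On the sulfonyl sulfur, 2-acetamidoethyl in place of phenyl gives a number 5 percentage points lower from compound 1 to compound 4 (within the scatter) and thus a second chain there stays within the scatter of phenyl. Nothing measured here offers an explanation for these steps.

Going by these compounds, whether a free amine or a carboxylic acid at the end of the ethyl chain, or a longer chain on the sulfonyl sulfur, would stay within the scatter remains open. Going by these compounds alone, compound 3 still shares no single-site step with the others.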